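Cyclohexyl replaced by isopropyl: notes on compound 3

The compounds below may be only part of what the source reports. "The series", "measured", "known", "first", "only" and "open" are said of these compounds alone.

Going by the values given here, compound 1 `c1ccc(OCc2nc3c(OCCCN4CCCCC4)cccc3n2CCCC2CCN(CCC3CCCCC3)CC2)cc1` has the higher of the two numbers measured so far in an in vitro assay on AV12 cells for binding affinity to Neuropeptide Y receptor type 1 (Homo sapiens) (a lower number here means a stronger inhibitor, a higher number a weaker inhibitor), at 0.285 nM. Among the compounds with values here, compound 2 `O=C(CCN1CCC(CCCn2c(COc3ccccc3)nc3c(OCCCN4CCCCC4)cccc32)CC1)c1ccccc1` gives 0.112 nM in this assay; the step of a 2.5-fold lower number from compound 1 to compound 2 (0.41 log units; beyond the scatter) is the only measured change on the saturated chain carbon concerned. Compound 3 `CC(C)CCN1CCC(CCCn2c(COc3ccccc3)nc3c(OCCCN4CCCCC4)cccc32)CC1` is unmeasured; it differs from compound 1 in one place: isopropyl in place of cyclohexyl on a saturated chain carbon, two bonds along the chain from an amine nitrogen in a ring. The measured step bears only loosely on this change, since it brings in a different group on the same saturated chain carbon; it shows that replacing cyclohexyl there need not weaken binding, but says nothing about isopropyl itself. No clear direction follows from the data, so the expectation is a step of a 1.4-fold higher number from compound 1 to compound 3 (0.15 log units; within the scatter) that stays close to the scatter. The estimate for compound 3 in this assay is 0.4 nM, within 0.15 nM to 1.2 nM.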

Compound 3, inhibition constant: 0.29 nM
The estimate for compound 3 lay 1.4-fold (0.14 log units) above the measured number; measured number inside the range.
By their numbers in this assay, from the lowest: compound 2; then compounds 1 and 3 (each within the scatter of the next).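

In this assay, the step (a 1.0-fold higher number from compound 1 to compound 3 (0.01 log units; within the scatter)) shows that at this saturated chain carbon, two bonds along the chain from an amine nitrogen in a ring, cyclohexyl can give way to isopropyl without a change beyond the scatter, so the ring and the 6 heavy atoms of cyclohexyl are not required for binding at this level. The second step (a 2.6-fold higher number from compound 2 to compound 3 (0.41 log units; beyond the scatter)) leaves benzoyl as the only one of the three groups shown that stands apart from the others, with compound 2 holding the lowest number.

The compounds shown do not tell whether the carbonyl or the phenyl ring of benzoyl goes with that lower number. An amine, a carboxylic acid or a longer chain at this carbon remains open, and no data at hand explain any of these steps.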